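Swapping the open amide for a lactam in the side chain

The source may report more compounds than this note shows. Statements on the series, on what has been measured and on what is new or still open speak of the compounds shown alone.

Four compounds share one core and differ only at a saturated chain carbon bound to an aromatic carbon and a saturated chain carbon. Compound 1 `CC(C)C(c1ncc[nH]1)c1ccc(-c2ccc3cccc(F)c3c2)[nH]c1=O` carries a 1H-imidazol-2-yl there, compound 2 `CC(C)C(c1nnc[nH]1)c1ccc(-c2ccc3cccc(F)c3c2)[nH]c1=O` a 4H-1,2,4-triazol-3-yl, and compound 3 `CC(C)NC(=O)CC(c1ccc(-c2ccc3cccc(F)c3c2)[nH]c1=O)C(C)C` an (isopropylcarbamoyl)methyl. In an ADME assay on microsomes from liver (Rattus norvegicus) for metabolic stability (on this read-out lower numbers stand for a shorter-lived compound and higher numbers for a longer-lived compound), compound 2 gives 0.552 h. Compound 1 gives only a limit, < 0.0667 h. Compound 3 also gives only a limit, < 0.0667 h. So compound 3 stands at the limit of < 0.0667 h in this assay, at which 2 of the 3 values shown sit, and the measured steps read as an at least 8.2-fold higher number from compound 1 to compound 2 (0.91 log units; beyond the scatter), an at least 8.2-fold lower number from compound 2 to compound 3 (0.91 log units; beyond the scatter), and a step that the two limits leave unreadable from compound 1 to compound 3.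

Compound 4 `CC(C)C(c1ccc(-c2ccc3cccc(F)c3c2)[nH]c1=O)N1CCCCC1=O` differs from compound 3 in one place: 2-oxopiperidin-1-yl in place of (isopropylcarbamoyl)methyl on a saturated chain carbon bound to an aromatic carbon and a saturated chain carbon. Going by the values given here, no measured step covers this exchange; the two steps that touch compound 3 only show that it sits at a limit, so the direction of this step is open. Compound 4 is expected to give 0.12 h in this assay, within 0.04 h to 0.45 h. That estimate amounts to an expected at least 1.7-fold higher number from compound 3 to compound 4 (0.25 log units; that floor lies within the scatter), with a real chance that only a limit is reported again.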

Compound 4, half-life: 0.102 h
Compound 4: the middle estimate sits 1.2-fold (0.07 log units) above what was measured; measured number inside the range.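

In this assay, compound 4 with its 2-oxopiperidin-1-yl gives a readable number at this position, whereas compound 1 and compound 3 stop at a limit: the limit of < 0.0667 h in this assay, at which 2 of the 4 values shown sit.

Closing the open amide into this ring gives an at least 1.5-fold higher number from compound 3 to compound 4 (0.18 log units; that floor lies within the scatter), and replacing the imidazole gives an at least 1.5-fold higher number from compound 1 to compound 4 (0.18 log units; that floor lies within the scatter), so a real gain over either group is possible but not established. The 4H-1,2,4-triazol-3-yl remains clearly ahead of the ring, with a 5.4-fold lower number from compound 2 to compound 4 (0.73 log units; beyond the scatter), and compound 2 is the longest-lived of the compounds shown.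

On these data alone, it stays open whether any difference between compound 3 and compound 4 comes from the ring itself or from the loss of the amide hydrogen. Also unknown is how a 2-oxopyrrolidin-1-yl or a carboxylic acid at this place would fare.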